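Chloro for methyl on the aryl ether of a triazine series

The source may report more compounds than this note shows. Statements on the series, on what has been measured and on what is new or still open speak of the compounds shown alone.

The measured compounds:
Compound 1 `CN1CCN(c2nc(N)nc(COc3cccc(Cl)c3)n2)CC1` gives 5820 nM in an assay on HEK293 cells for displacement of a labelled ligand from 5-hydroxytryptamine receptor 7 (Homo sapiens), read by radioligand binding, with a stated time of 1 h; a lower number here means a stronger inhibitor, a higher number a weaker inhibitor.
Compound 2 `Cc1cccc(OCc2nc(N)nc(N3CCN(C)CC3)n2)c1` gives 10700 nM in this assay.
Compound 3 `Cc1cc(Cl)ccc1OCc1nc(N)nc(N2CCN(C)CC2)n1` gives 15200 nM in this assay.

All three share a core and differ only in the aryl group on the ether oxygen. Compound 2 and compound 3 differ in that group: 4-chloro-2-methylphenyl in place of 3-methylphenyl on an oxygen on a saturated carbon. Between them the number moves by a 1.4-fold higher number from compound 2 to compound 3 (0.15 log units; within the scatter). Compound 1 and compound 3 differ by a larger step, a 2.6-fold higher number from compound 1 to compound 3 (0.42 log units; beyond the scatter), so compound 3 stands with the highest number of the three, though its gap to compound 2 is within the scatter.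

Compound 4 `CN1CCN(c2nc(N)nc(COc3ccc(Cl)cc3Cl)n2)CC1` has not yet been measured. It arises from compound 3 by chloro in place of methyl on an aromatic carbon. The same kind of change, though not the same change, connects compound 2 to compound 1: chloro in place of methyl on an aromatic carbon. There the place is meta to a large group, whereas in compound 4 the place is ortho to a large group and meta to a chloro group. That earlier step was a 1.8-fold lower number from compound 2 to compound 1 (0.26 log units; within the scatter).

On that single precedent, compound 4 is expected to move by about a 1.7-fold lower number from compound 3 to compound 4 (0.23 log units; within the scatter) from compound 3, because the step of a 1.8-fold lower number from compound 2 to compound 1 (0.26 log units; within the scatter) is the only one available for this kind of change. The estimate for compound 4 is 9000 nM, with a likely range from 3000 nM to 25000 nM.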

Compound 4, inhibition constant: 3800 nM
Estimate against measurement, compound 4: 2.4-fold (0.37 log units) above; measured number inside the range.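

Chloro in place of methyl, on the aromatic carbon ortho to a large group and meta to a chloro group, gives a 4.0-fold lower number from compound 3 to compound 4 (0.60 log units; beyond the scatter) in this assay, and this step cannot be told apart from the earlier one on the other core: the same change on two cores in this assay, a 1.8-fold lower number (0.26 log units; within the scatter) from compound 2 to compound 1 and a 4.0-fold lower number (0.60 log units; beyond the scatter) from compound 3 to compound 4, 2.2-fold (0.34 log units) apart, within the scatter of two such steps

Within these two pairs, then, the change carries from one core to the other without a detectable difference in size, and the 2,4-dichlorophenyl group gives a 2.8-fold lower number from compound 2 to compound 4 (0.45 log units; beyond the scatter), while a 1.5-fold lower number from compound 1 to compound 4 (0.19 log units; within the scatter) leaves the 2,4-dichlorophenyl and 3-chlorophenyl groups unranked. Among the compounds shown here, this does not show that the change has a fixed size or that it would hold on a third core, since there are only two pairs, the change sits at a different place on the aromatic ring in each, and only one of the two steps lies beyond the scatter.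

The compounds shown leave open whether fluoro, bromo or methoxy at the same place would follow chloro. They also leave open whether the step would survive on a core in which an amine takes the place of the ether oxygen, and all of this rests on this assay alone.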